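Hexyl extension of the acetamido propyl side chain

The source may report more compounds than this note shows. Statements on the series, on what has been measured and on what is new or still open speak of the compounds shown alone.

Compound 2 `CC[C@H]1OC(=O)[C@H](C)[C@@H](O[C@H]2C[C@@](C)(OC)[C@@H](O)[C@H](C)O2)[C@H](C)[C@@H](O[C@@H]2O[C@H](C)C[C@H](N(C)C)[C@H]2O)[C@](C)(O)C[C@@H](C)CN(CCCNC(C)=O)[C@H](C)[C@@H](O)[C@]1(C)O` holds the lowest of the three numbers in a physicochemical assay for lipophilicity, read by HPLC, measured as chromatographic lipophilicity, at pH 7.4 (on this read-out lower numbers stand for lower lipophilicity and higher numbers for higher lipophilicity), giving 2.06. Compound 1 `CC[C@H]1OC(=O)[C@H](C)[C@@H](O[C@H]2C[C@@](C)(OC)[C@@H](O)[C@H](C)O2)[C@H](C)[C@@H](O[C@@H]2O[C@H](C)C[C@H](N(C)C)[C@H]2O)[C@](C)(O)C[C@@H](C)CN(CCCNC(=O)C2CCC2)[C@H](C)[C@@H](O)[C@]1(C)O` gives 2.31 and compound 3 `CC[C@H]1OC(=O)[C@H](C)[C@@H](O[C@H]2C[C@@](C)(OC)[C@@H](O)[C@H](C)O2)[C@H](C)[C@@H](O[C@@H]2O[C@H](C)C[C@H](N(C)C)[C@H]2O)[C@](C)(O)C[C@@H](C)CN(C)[C@H](C)[C@@H](OCCCNC(C)=O)[C@]1(C)O` gives 2.41 in this assay. The change to compound 4 `CCCCCCCC(=O)NCCCN1C[C@H](C)C[C@@](C)(O)[C@H](O[C@@H]2O[C@H](C)C[C@H](N(C)C)[C@H]2O)[C@@H](C)[C@H](O[C@H]2C[C@@](C)(OC)[C@@H](O)[C@H](C)O2)[C@@H](C)C(=O)O[C@H](CC)[C@@](C)(O)[C@H](O)[C@H]1C` is hexyl in place of hydrogen on a saturated chain carbon bound to a carbonyl carbon. Among the measured compounds shown here, the only step that bears on it is the one on the same carbonyl, a number 0.25 log units lower from compound 1 to compound 2 (within the scatter), which exchanged three ring carbons for a methyl. The present change adds six chain carbons and no other feature, so a step in this assay of clearly larger size and upward is expected for compound 4 because a number 0.25 log units lower from compound 1 to compound 2 (within the scatter) already pointed that way for fewer carbons. Compound 4 is therefore estimated at 3.1, within 2.4 to 3.9, an expected step of a number 1.04 log units higher from compound 2 to compound 4 (beyond the scatter).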

Compound 4, distribution coefficient: 3.74
For compound 4 the middle estimate is 0.64 log units below the measured one; the range from low to high includes it.
By their numbers in this assay, from the lowest: compounds 2, 1 and 3 (each within the scatter of the next, the first and the last beyond it); then compound 4.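

In this assay, the side-chain amide carbonyl tolerates far more than the earlier within-scatter step suggested: hexyl in place of hydrogen on a saturated chain carbon bound to a carbonyl carbon gives a large rise (a number 1.68 log units higher from compound 2 to compound 4 (beyond the scatter)). Measured against the cyclobutyl group, the heptyl group also gives a large rise (a number 1.43 log units higher from compound 1 to compound 4 (beyond the scatter)), so the acyl group at this position can shift the read-out well beyond the scatter. No available evidence bears on the cause of these steps.

As far as these compounds go, whether a butyl or a longer chain would fit the same trend remains open. So does the effect of a chain carrying an amine or a carboxylic acid.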